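Methoxypyridine in Place of a Branched Alkene

The source may report more compounds than this note shows. Statements on the series, on what has been measured and on what is new or still open speak of the compounds shown alone.

Compound 1 `CCCCNc1nc(N)nc2ccn(CC=C(C)C)c12` is the reference here. In an assay on HEK293 cells for agonist activity at Toll-like receptor 8 (Homo sapiens), read by a luciferase reporter, with a stated time of 6 h (a lower number here means that less compound is needed, a higher number that more compound is needed for the effect), compound 1 gives only a limit, > 25 uM, not a measured number. Compound 2 `CCCCNc1nc(N)nc2ccn(Cc3cn4ccccc4n3)c12` also returns a limit in this assay, > 25 uM. Compound 3 `CCCCNc1nc(N)nc2ccn(Cc3ncc(C)c(OC)c3C)c12` likewise gives a limit in this assay, > 25 uM. So compound 1 stands where everything measured stands, because the limit of > 25 uM in this assay, at which 3 of the 3 values shown sit, covers all three values. Compound 4 `CCCCNc1nc(N)nc2ccn(Cc3ncccc3OC)c12` is not yet measured. It differs from compound 1 in one place: 3-methoxypyridin-2-yl in place of 2-methylprop-1-en-1-yl on a saturated chain carbon bound to an aromatic nitrogen. Within the data shown here, no step between measured compounds is available, so nothing here shows this kind of change moving the read-out. The expected step of a number no higher from compound 1 to compound 4 (the limit leaves the size open) is therefore none beyond the scatter. Compound 4 is estimated at 25 uM, with a range from 5 uM to 50 uM.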

Compound 4, minimum effective concentration: 0.59 uM
For compound 4 the middle estimate is 42-fold (1.63 log units) above the measured one, and the stated range ends above it.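

At this position the group matters a great deal: in this assay, 3-methoxypyridin-2-yl in place of 2-methylprop-1-en-1-yl gives an at least 42-fold lower number from compound 1 to compound 4 (1.62 log units; beyond the scatter). Compound 4 is also the first compound here with a measured number rather than a limit, and it stands apart from the others: the limit of > 25 uM in this assay, at which 3 of the 4 values shown sit.

The compounds shown do not tell whether the pyridine ring or the methoxy group carries this step. A plain pyridin-2-yl without the methoxy, or a 3-ethoxypyridin-2-yl, would be needed to separate the two.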